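The source may report more compounds than this note shows. Statements on the series, on what has been measured and on what is new or still open speak of the compounds shown alone.

Measured compounds:
compound 1, `COc1cc2c(cc1OC)C(CC(=O)O)CC2`: 26.7%
compound 2, `COc1cc2c(cc1OC)C(CC(=O)N(C)C)CC2`: 23.3%

Both were tested in a functional assay on the whole organism (strain Wistar) for inhibition, with Rattus norvegicus as the target, read by paw edema, with stated times of 60 min and 24 h, at a dose of 100 mg/kg by the oral route; a higher number here means more inhibition at the dose given (going by the name of the read-out), a lower number less inhibition. Compound 1 stands highest of the two numbers, but its nearest neighbour, compound 2, lies within the usual scatter, so the two read as the same. Within the data shown here, the one measured step, a number 3.4 percentage points lower from compound 1 to compound 2 (within the scatter), shows that replacing the hydroxy on the carbonyl carbon with dimethylamino left the read-out unchanged beyond the scatter.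

Compound 3, `COc1cc2c(cc1OC)C(CC(=O)NC(C)C)CC2`, has not yet been measured. It differs from compound 1 in one place: isopropylamino in place of hydroxy on a carbonyl carbon. The step to compound 2 bears on this change, since both exchange the same hydroxy for an amine nitrogen. Because that step, a number 3.4 percentage points lower from compound 1 to compound 2 (within the scatter), was within the scatter, the expected step of a number 1.7 percentage points lower from compound 1 to compound 3 (within the scatter) is none beyond the scatter. The estimate for compound 3 is therefore 25%, with a range from 10% to 40%.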

Compound 3, a percentage reported as inhibition, in the whole organism at one dose (the size of the read-out at that dose, not a potency): 30%
The estimate for compound 3 lay 5 percentage points below the measured number; low and high end bracket the measured number.
By their numbers in this assay, from the lowest: compounds 2, 1 and 3 (each within the scatter of the next).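

In this assay, a second amine on the carbonyl carbon now gives a number 3.3 percentage points higher from compound 1 to compound 3 (within the scatter), so a group of 4 heavy atoms in place of hydroxy still cannot be told apart from the carboxylic acid. Among these compounds, the compounds also allow a first direct comparison of two amines at this place, and isopropylamino in place of dimethylamino gives a number 6.7 percentage points higher from compound 2 to compound 3 (within the scatter), so hydroxy, dimethylamino and isopropylamino all read alike here. Nothing available explains this sameness.

Going by these compounds, whether any group on this carbonyl carbon can move the read-out beyond the scatter remains open, for example piperidine, benzylamino or a longer chain such as n-octylamino. The compounds shown also leave open what a change in the shared core would do, such as ethoxy in place of methoxy.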